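The source may report more compounds than this note shows. Statements on the series, on what has been measured and on what is new or still open speak of the compounds shown alone.

Among the compounds with values here, compound 3 `ONCCCc1c[nH]c2ccc(F)cc12` gives 21 nM in an assay on isolated protein for inhibition of Myeloperoxidase (Homo sapiens), read by ELISA, with a stated time of 5 min (on this read-out higher numbers stand for weaker inhibition and lower numbers for stronger inhibition), the lowest of the three numbers measured so far. Compound 1 `NCC(N)CCc1c[nH]c2ccc(F)cc12` gives 26 nM in this assay, and the gap is small (a 1.2-fold lower number from compound 1 to compound 3 (0.09 log units; within the scatter)). Compound 2 `CNC(=O)CCCc1c[nH]c2ccc(F)cc12` gives 95 nM in this assay, a modest gap (a 4.5-fold lower number from compound 2 to compound 3 (0.66 log units; beyond the scatter)).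

Compound 4 `CCSCCc1c[nH]c2ccc(F)cc12` has not yet been measured. It differs from compound 3 by ethylsulfanyl in place of (hydroxyamino)methyl on a saturated chain carbon, two bonds along the chain from an aromatic carbon. Within the data shown here, two measured steps bear on this change. The step of a 3.7-fold higher number from compound 1 to compound 2 (0.56 log units; beyond the scatter) shows that giving up the 1,2-diaminoethyl group for one with a carbonyl costs potency, and the step of a 4.5-fold lower number from compound 2 to compound 3 (0.66 log units; beyond the scatter) shows that returning to a group with two hydrogen-bond donors regains it. Compound 4 keeps no donor at all in that chain, so a weakening beyond the scatter in this assay is expected, somewhat larger than those two steps.

Compound 4 is therefore expected to give 200 nM in this assay, within a range from 50 nM to 1000 nM. The expected step is a 9.5-fold higher number from compound 3 to compound 4 (0.98 log units; beyond the scatter).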

Compound 4, half-maximal inhibitory concentration: > 100 nM
Compound 4 was reported as a limit (the forecaster's own chance of this, stated with the estimate: 10%); the middle value lies beyond the limit too.
By their numbers in this assay, from the lowest: compounds 3 and 1 (each within the scatter of the next); then compound 2. At a limit, above all of these: compound 4.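

In this assay compound 4 is reported only as a limit, not as a number: the limit of > 100 nM in this assay, at which 1 of the 4 values shown sits. Even so, ethylsulfanyl in place of (hydroxyamino)methyl, a swap that keeps 3 heavy atoms but takes hydrogen-bond donors from 2 to 0 on this saturated chain carbon, gives an at least 4.7-fold higher number from compound 3 to compound 4 (0.67 log units; beyond the scatter), and the step from the 1,2-diaminoethyl group, an at least 3.8-fold higher number from compound 1 to compound 4 (0.58 log units; beyond the scatter), also lies beyond the scatter, so at this position the number is not held by the count of heavy atoms alone. The step of an at least 1.0-fold higher number from compound 2 to compound 4 (0.02 log units; that floor lies within the scatter) is only a floor within the scatter, which leaves that pair without an order.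

On these data alone, how far the true number of compound 4 lies past its limit stays open. So does whether an ethoxy group or a hydroxyl group in place of ethylsulfanyl would stay with compound 4 or come back towards compound 3.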